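The source may hold more compounds than are shown below. What is called first, only, known or untested is meant among the compounds shown, and "the series" means these compounds.

- compound 1 `COc1cc(C(C)=O)ccc1OCCCN1CCC(=C(c2ccc(F)cc2)c2ccc(F)cc2)CC1` gives 3.98 nM
- compound 2 `CCc1ccc(OCCCN2CCC(C(c3ccc(F)cc3)c3ccc(F)cc3)CC2)c(OC)c1` gives 2.51 nM

In a functional assay (aorta) with Oryctolagus cuniculus as the target (on this read-out higher numbers stand for weaker binding and lower numbers for tighter binding), compound 1 at 3.98 nM and compound 2 at 2.51 nM lie within the usual scatter of each other. They differ in more than one place, so no single change has a measured step. Next is compound 3 `NC(=O)c1ccc(OCCCN2CCC(C(c3ccc(F)cc3)c3ccc(F)cc3)CC2)cc1`, where the change is 4-carbamoylphenyl in place of 4-ethyl-2-methoxyphenyl on an oxygen on a saturated carbon. Neither measured compound carries 4-carbamoylphenyl, so the size of this step rests on judgement and the range stays wide. A modest move towards a higher number in this assay, meaning weaker binding, is expected, and the estimated change is a 2.4-fold higher number from compound 2 to compound 3 (0.38 log units; beyond the scatter). The estimate for compound 3 is 6 nM, with an expected range of 1.5 nM to 25 nM.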

Compound 3, dissociation constant: 31.6 nM
The estimate for compound 3 lay 5.3-fold (0.72 log units) below the measured number, outside the stated range (above it).
By their numbers in this assay, from the lowest: compounds 2 and 1 (each within the scatter of the next); then compound 3.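

In this assay the change to 4-carbamoylphenyl from 4-ethyl-2-methoxyphenyl on an oxygen on a saturated carbon gives a 13-fold higher number from compound 2 to compound 3 (1.10 log units; beyond the scatter) and so weaker binding. Among the compounds shown here, this is the first single change with a measured step, and it shows that the group on this oxygen is not interchangeable: the aryl group here can move the read-out well beyond the scatter. No evidence at hand accounts for the size of this step.

The ethyl and methoxy groups leave together as the carbamoyl enters, and the compounds shown do not separate these parts of the change. Also open, as far as these compounds go, is whether a nitrile or a carboxylic acid in place of the carbamoyl would give a step of similar size.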